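A few compounds are considered here, and "the series" means these few. Any claim that something is new, unique, unknown or untested is made for them only; others in the source may bear on it.

For the measured compounds named here, compound 1, `CCNC(=O)NC1=CS(=O)(=O)O[C@@]12[C@@H](CO[Si](C)(C)C(C)(C)C)O[C@@H](n1cc(C)c(=O)n(C)c1=O)[C@@H]2O[Si](C)(C)C(C)(C)C`, is one of two compounds measured in a functional assay on HEL cells (Homo sapiens); a higher number here means that more compound is tolerated, a lower number that less compound is tolerated; compound 1 gives 10000 nM, the highest of the two numbers, and its nearest neighbour compound 2, `Cc1cn([C@@H]2O[C@H](CO[Si](C)(C)C(C)(C)C)[C@@]3(OS(=O)(=O)C=C3NC(=O)c3ccccc3)[C@H]2O[Si](C)(C)C(C)(C)C)c(=O)n(C)c1=O`, gives 9700 nM. Going by the values given here, the only measured step, a 1.0-fold lower number from compound 1 to compound 2 (0.01 log units; within the scatter), stays within the scatter. Compound 3, `Cc1cn([C@@H]2O[C@H](CO[Si](C)(C)C(C)(C)C)[C@@]3(OS(=O)(=O)C=C3NCC(=O)O)[C@H]2O[Si](C)(C)C(C)(C)C)c(=O)n(C)c1=O`, differs from compound 1 as follows: carboxymethyl in place of ethylcarbamoyl on an amine nitrogen. Among the compounds with values here, no measured step covers this change; the one recorded step left the number unchanged, so no step beyond the scatter is expected in this assay, no change at the digits printed from compound 1 to compound 3 (within the scatter). Compound 3 is therefore expected to give 10000 nM, estimated between 4000 nM and 25000 nM.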

Compound 3, half-maximal cytotoxic concentration: 136000 nM
Compound 3: middle estimate off by 14-fold (1.13 log units), on the low side; the whole stated range lies below it.
By their numbers in this assay, from the lowest: compounds 2 and 1 (each within the scatter of the next); then compound 3.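

In (this assay), the group on this amine nitrogen does matter. Carboxymethyl in place of ethylcarbamoyl gives (a 14-fold higher number from compound 1 to compound 3 (1.13 log units; beyond the scatter)), and carboxymethyl in place of benzoyl gives (a 14-fold higher number from compound 2 to compound 3 (1.15 log units; beyond the scatter)), whereas the earlier swap between the two carbonyl-bearing groups moved nothing beyond the scatter. No measured evidence accounts for this rise. The compounds shown cannot separate the role of the free acid from that of the missing carbonyl on the nitrogen. A methyl ester of the acid, a plain ethyl group or a longer acid chain on this nitrogen would remain to be read.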